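The source may hold more compounds than are shown below. What is called first, only, known or untested is meant among the compounds shown, and "the series" means these compounds.

Working notes on the series in a functional assay on HCT-116 cells (Homo sapiens) for inhibition, read by sulforhodamine B assay, with a stated time of 48 h; on this read-out higher numbers stand for weaker inhibition and lower numbers for stronger inhibition.

Of the compounds shown here, three have numbers so far. Compound 1 `CO[C@@H]1CC=C2NN(c3ccc(C)cc3)C(=O)C[C@]2(C)O1` gives 28700 nM in this assay. Compound 2 `CO[C@@H]1CC=C2NN(c3ccc(C)cc3)C(=O)C[C@]2(c2ccncc2)O1` gives 7400 nM in this assay. Compound 3 `COc1cc(OC)cc(N2NC3=CC[C@@H](OC)O[C@@]3(C)CC2=O)c1` gives 24300 nM in this assay. Among the measured compounds shown here, the single change from compound 1 to compound 2, (pyridin-4-yl in place of methyl on a saturated ring carbon), produced a 3.9-fold lower number from compound 1 to compound 2 (0.59 log units; beyond the scatter). Compound 3 and compound 1 differ in more than one place, and the difference between the two cores is not broken down here; their two values lie within the scatter of each other, so no order between them is drawn.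

Compound 4 `COc1cc(OC)cc(N2NC3=CC[C@@H](OC)O[C@@]3(c3ccncc3)CC2=O)c1` is not yet measured. Relative to compound 3 it carries pyridin-4-yl in place of methyl on a saturated ring carbon. This is the same kind of change as that from compound 1 to compound 2, not the same: in compound 2 the new group sits on a saturated ring carbon of a six-membered non-aromatic ring with 1 oxygen, next to the ring oxygen and next to the ring atom that bears a fused ring, whereas in compound 4 it sits on a saturated ring carbon of a six-membered non-aromatic ring with 2 nitrogen, two ring bonds from the ring nitrogen and three ring bonds from the ring nitrogen.

For compound 4 a step of a 3.2-fold lower number from compound 3 to compound 4 (0.51 log units; beyond the scatter) is expected in this assay. That expectation rests on compound 1 and compound 2 alone, because a 3.9-fold lower number from compound 1 to compound 2 (0.59 log units; beyond the scatter) is the only measured outcome of this kind of change, and the different surroundings of the place widen the uncertainty. Compound 4 is accordingly estimated at 7500 nM, with an expected range from 3000 nM to 19000 nM.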

Compound 4, half-maximal inhibitory concentration: 6500 nM
Compound 4: the middle estimate sits 1.2-fold (0.06 log units) above what was measured; the range from low to high includes it.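

In this assay, pyridin-4-yl in place of methyl on a saturated ring carbon gives a 3.7-fold lower number from compound 3 to compound 4 (0.57 log units; beyond the scatter), and this step matches the earlier one within the scatter: the same change on two cores in this assay, a 3.9-fold lower number (0.59 log units; beyond the scatter) from compound 1 to compound 2 and a 3.7-fold lower number (0.57 log units; beyond the scatter) from compound 3 to compound 4, 1.0-fold (0.02 log units) apart, within the scatter of two such steps

For these two matched pairs, the change therefore carries from the core of compound 1 to the core of compound 3 with no measurable loss or gain in size, even though its surroundings differ between the two cores. Among the compounds shown here, this rests on only two pairs in a single assay, so it sets no general rule for other cores or other read-outs, and it does not show why the number falls or whether the two steps share a cause.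

The compounds shown leave open whether a plain phenyl ring or pyridin-3-yl on the same carbon would give a step of similar size, and so whether the ring nitrogen or its placement matters at all. They also leave open how a longer alkyl chain, an amine or a carboxylic acid at that place would read in this assay, and whether any such group would carry between the two cores as faithfully as pyridin-4-yl does.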